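The source may hold more compounds than are shown below. What is called first, only, known or untested is meant among the compounds shown, and "the series" means these compounds.

Measured compounds:
compound 1 `CC(C)OC(=O)C(O)Cn1cnc2c(N)ncnc21`: > 400 ug/mL, a limit of the assay
compound 2 `COC(=O)C(O)Cn1cnc2c(N)ncnc21`: > 400 ug/mL, a limit of the assay
compound 3 `Nc1ncnc2c1ncn2CC(O)C(=O)OC1CCCCC1`: 100 ug/mL

In a functional assay on PRK cells (Oryctolagus cuniculus) for cytotoxicity (on this read-out lower numbers stand for higher toxicity in this test and higher numbers for lower toxicity in this test), compound 3 holds the only number shown; the two further values are limits (the limit of > 400 ug/mL in this assay, at which 2 of the 3 values shown sit). Compound 4 `CCC(C)OC(=O)C(O)Cn1cnc2c(N)ncnc21` differs from compound 3 by sec-butyl in place of cyclohexyl on an oxygen next to a carbonyl group. Within the data shown here, two measured steps bear on this change: an at least 4.0-fold lower number from compound 1 to compound 3 (0.60 log units; beyond the scatter) and an at least 4.0-fold lower number from compound 2 to compound 3 (0.60 log units; beyond the scatter), both running from a smaller acyclic alkyl ester toward the cyclohexyl ester. Returning from cyclohexyl to sec-butyl is the reverse direction, so a higher number beyond the scatter in this assay is expected, with a fair chance that only a limit is reported. The estimate for compound 4 is 250 ug/mL, expected to lie between 100 ug/mL and 400 ug/mL. The expected step is a 2.5-fold higher number from compound 3 to compound 4 (0.40 log units; beyond the scatter).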

Compound 4, minimum cytotoxic concentration: > 400 ug/mL
Compound 4 was reported as a limit; the forecaster's own chance of this, stated with the estimate: 50%; middle value at least 1.6-fold (0.20 log units) from the limit.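

In this assay, sec-butyl in place of cyclohexyl on an oxygen next to a carbonyl group gives an at least 4.0-fold higher number from compound 3 to compound 4 (0.60 log units; beyond the scatter), so sec-butyl joins methyl and isopropyl on this oxygen and compound 3 stands alone. Compound 3, with cyclohexyl, is the only ester in the set that gives a number rather than a limit: the limit of > 400 ug/mL in this assay, at which 3 of the 4 values shown sit. The steps among compound 1, compound 2 and compound 4 cannot be read.

Going by these compounds, whether the lower number of compound 3 follows the ring or the size of the group stays open. A longer chain such as hexyl, or a cyclopentyl ester, on this oxygen would separate the two.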